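Oxan-4-yl replaces cyclopropylmethyl on a shared purine-like core

The source may report more compounds than this note shows. Statements on the series, on what has been measured and on what is new or still open speak of the compounds shown alone.

Compound 1 `CN(C)C1CCN(c2ccc(Nc3ncc4nc(Sc5ccccc5)n(C5CCOCC5)c4n3)cc2)CC1`: 29.4 nM
Compound 2 `CN1CCN(c2ccc(Nc3ncc4nc(Sc5ccccc5)n(CC5CC5)c4n3)cc2)CC1`: 660 nM

In a functional assay on HCC827 cells (Homo sapiens) for antiproliferative activity, read by MTT assay, with a stated time of 72 h (a lower number here means a stronger inhibitor, a higher number a weaker inhibitor), compound 2 gives 660 nM, the highest of the two numbers measured; compound 1 gives 29.4 nM, a gap beyond the scatter. Compound 3 `CN1CCN(c2ccc(Nc3ncc4nc(Sc5ccccc5)n(C5CCOCC5)c4n3)cc2)CC1` is not yet measured. It differs from compound 2 by oxan-4-yl in place of cyclopropylmethyl on an aromatic nitrogen, and it thereby carries the same oxan-4-yl group as compound 1. Going by the values given here, no step between measured compounds isolates this change, but compound 1, which carries that group, sits far lower. The step of a 6.6-fold lower number from compound 2 to compound 3 (0.82 log units; beyond the scatter) is expected to be downward and beyond the scatter. Compound 3 is expected to give 100 nM, within a range of 30 nM to 350 nM.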

Compound 3, half-maximal inhibitory concentration: 42.6 nM
Beside the measured number, compound 3's estimate is 2.3-fold (0.37 log units) above it, and the stated range covers the measured number.
By their numbers in this assay, from the lowest: compounds 1 and 3 (each within the scatter of the next); then compound 2.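

In this assay, oxan-4-yl in place of cyclopropylmethyl on an aromatic nitrogen now stands as a single change, giving a 15-fold lower number from compound 2 to compound 3 (1.19 log units; beyond the scatter). With 4-methylpiperazin-1-yl in place of 4-(dimethylamino)piperidin-1-yl on an aromatic carbon, the other step is a 1.4-fold higher number from compound 1 to compound 3 (0.16 log units; within the scatter), so the large gap seen earlier follows the group on the nitrogen rather than this swap. Nothing measured here gives a reason for the step. As far as these compounds go, whether piperidin-4-yl, with a ring amine where oxan-4-yl has its oxygen, or cyclohexyl, with carbon there, would hold the number stays open.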